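Swapping the Group on the Amide Nitrogen

A few compounds are considered here, and "the series" means these few. Any claim that something is new, unique, unknown or untested is made for them only; others in the source may bear on it.

Compound 1, with the structure `CCOC(=O)C1=C(C)NC(C)=C(C(=O)OCC)C1c1ccc(OCC(=O)Nc2ccc(C)cc2)cc1`, was tested in a functional assay on the whole organism (strain Wistar) for inhibition, with Rattus norvegicus as the target, read by paw edema, with stated times of 30 min and 3 h, at a dose of 20 mg/kg (a lower number here means less inhibition, a higher number more inhibition at the dose given (going by the name of the read-out)), where compound 1 gives 61.1%. Compound 2, with the structure `CCOC(=O)C1=C(C)NC(C)=C(C(=O)OCC)C1c1ccc(OCC(=O)NNC(=O)c2cccs2)cc1`, carries a different group on its amide-type nitrogen, and in this assay compound 2 gives 61.1%. The step of no change at the digits printed from compound 1 to compound 2 (within the scatter) shows that this exchange made no difference beyond the scatter, so compound 2 stands level with compound 1 on the numbers available.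

Compound 3, with the structure `CCOC(=O)C1=C(C)NC(C)=C(C(=O)OCC)C1c1ccc(OCC(=O)NN2C(=O)c3ccccc3C2=O)cc1`, differs from compound 2 only at that same amide-type nitrogen: a group of 11 heavy atoms (8 carbon, 1 nitrogen, 2 oxygen; one five-membered non-aromatic ring with 1 hetero atom, one six-membered aromatic ring of carbon only) in place of a group of 8 heavy atoms (5 carbon, 1 nitrogen, 1 oxygen, 1 sulfur; one five-membered aromatic ring with 1 hetero atom), on an amide-type nitrogen. Among the measured compounds shown here, the one measured step that bears on this change is the step from compound 1 to compound 2, which altered the group on the same nitrogen and gave no change within the scatter. On that evidence a step of about a number 1.1 percentage points lower from compound 2 to compound 3 (within the scatter) is expected for compound 3, that is, none beyond the scatter. In this assay compound 3 is therefore estimated at 60%, with a range from 46% to 72% expected.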

Compound 3, a percentage reported as inhibition, in the whole organism at one dose (the size of the read-out at that dose, not a potency): 59.3%
Compound 3: the middle estimate sits 0.7 percentage points above what was measured; low and high end bracket the measured number.
By their numbers in this assay, from the lowest: compounds 3, 1 and 2 (each within the scatter of the next).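

Swapping the ((thiophen-2-yl)carbonyl)amino group for the group of compound 3, with its five-membered non-aromatic ring fused to a six-membered aromatic ring, gives a number 1.8 percentage points lower from compound 2 to compound 3 (within the scatter) in this assay, and swapping the 4-methylphenyl group for that same group gives a number 1.8 percentage points lower from compound 1 to compound 3 (within the scatter). The amide-type nitrogen has now carried three differently built groups with no difference beyond the scatter, and this includes a change from 1 hydrogen-bond donor in the ((thiophen-2-yl)carbonyl)amino group to 0 in the group that enters. No information is available that would explain why these exchanges leave the read-out level.

From the compounds shown here alone, all three groups on this nitrogen contain a ring and span from 7 to 11 heavy atoms, so it remains open whether a much smaller group such as methyl, or an open chain such as n-butyl, would keep the read-out at the same level. The shared core also stays the same in all three compounds, so these results say nothing about a carboxylic acid in place of either ethyl ester, and a read-out at one dose does not show whether the three compounds match in potency.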